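The source may report more compounds than this note shows. Statements on the series, on what has been measured and on what is new or still open speak of the compounds shown alone.

Measured so far in an ADME assay on microsomes from liver (Homo sapiens) for metabolic stability (on this read-out higher numbers stand for fast clearance and lower numbers for slow clearance), are these compounds:

- compound 1 `Cc1ccc2[nH]c(C(=O)N[C@H]3CN(S(=O)(=O)c4ccccc4)C[C@@H]3C(=O)NC[C@H]3CCCN3)cc2c1` gives < 3 mL.min-1.g-1 as a limit
- compound 2 `Cc1ccc2[nH]c(C(=O)N[C@H]3CN(S(=O)(=O)c4ccccc4)C[C@@H]3C(=O)N[C@H]3CCCNC3)cc2c1` gives < 3 mL.min-1.g-1 as a limit
- compound 3 `O=C(N[C@H]1CN(S(=O)(=O)c2ccccc2)C[C@@H]1C(=O)N[C@H]1CCCNC1)c1cc(C2CC2)n[nH]1` gives < 3 mL.min-1.g-1 as a limit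

Compound 3 stands at < 3 mL.min-1.g-1 as a limit of this assay and not as a number. The whole set comes down to the limit of < 3 mL.min-1.g-1 in this assay, at which 3 of the 3 values shown sit, and gives no order among the three compounds.

Compound 4 `O=C(N[C@H]1CN(S(=O)(=O)c2ccccc2)C[C@@H]1C(=O)N[C@H]1CCCNC1)c1cc(-c2ccccc2)on1` has not yet been measured. Its difference from compound 3 is 5-phenyl-1,2-oxazol-3-yl in place of 3-cyclopropyl-1H-pyrazol-5-yl on a carbonyl carbon and the exchange takes place on a carbonyl carbon, with 5-phenyl-1,2-oxazol-3-yl in place of 3-cyclopropyl-1H-pyrazol-5-yl.

The closest measured change is a step that the two limits leave unreadable from compound 2 to compound 3 at that same carbonyl carbon. The other is a step that the two limits leave unreadable from compound 1 to compound 2 with piperidin-3-yl in place of (pyrrolidin-2-yl)methyl on an amide-type nitrogen. Neither has a readable size, and neither fixes the size of the new step. Still, both groups measured on that carbonyl carbon leave the compound at the limit. The expected change is therefore small, estimated as a number no lower from compound 3 to compound 4 (the limit leaves the size open) and if anything towards faster clearance. For compound 4 the estimate is 3 mL.min-1.g-1 with an expected range from 1.5 mL.min-1.g-1 to 9 mL.min-1.g-1 and a fair chance of another limit.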

Compound 4, intrinsic clearance in microsomes: < 3 mL.min-1.g-1
Compound 4: no number, only a limit; the forecaster's own chance of this, stated with the estimate: 55%; the middle value sits exactly at the limit.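

In this assay compound 4 gives < 3 mL.min-1.g-1, which is a limit and not a number. Among the compounds shown here, its steps from compound 3 and from compound 2 therefore cannot be read, and no new step emerges. Whether compound 1, compound 2, compound 3 and compound 4 differ at all in this assay stays open: the limit of < 3 mL.min-1.g-1 in this assay, at which 4 of the 4 values shown sit.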